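The compounds below may be only part of what the source reports. "The series", "measured", "known", "first", "only" and "open" are said of these compounds alone.

Compound 1 `CC(C)CCn1nc(C2CCCCC2)c(O)c(C2=NS(=O)(=O)c3cc(NS(C)(=O)=O)ccc3N2)c1=O`: > 1000 nM
Compound 2 `CC(C)=Cc1nn(CCC(C)C)c(=O)c(C2=NS(=O)(=O)c3cc(NS(C)(=O)=O)ccc3N2)c1O`: > 1000 nM

In an ADME assay on Huh-7 cells (Homo sapiens) for cytotoxicity, with a stated time of 72 h (a lower number here means that less compound is tolerated, a higher number that more compound is tolerated), compound 2 gives > 1000 nM, which is a limit and not a number. Compound 1 sits there too, as the evidence shows: the limit of > 1000 nM in this assay, at which 2 of the 2 values shown sit. Compound 3 `CC(C)CCn1nc(CCC(F)(F)F)c(O)c(C2=NS(=O)(=O)c3cc(NS(C)(=O)=O)ccc3N2)c1=O` has 3,3,3-trifluoropropyl in place of 2-methylprop-1-en-1-yl on an aromatic carbon. Among the measured compounds shown here, the one measured step at this place is a step that the two limits leave unreadable from compound 1 to compound 2, so it gives no size to build on, and no step beyond the scatter is expected in this assay. The step expected is a step that the limit leaves unreadable from compound 2 to compound 3. The estimate for compound 3 is 2000 nM, within an estimated range of 1000 nM to 10000 nM.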

Compound 3, half-maximal cytotoxic concentration: > 33000 nM
Compound 3 was reported as a limit; the forecaster's own chance of this, stated with the estimate: 90%; at least 16-fold (1.21 log units) between middle value and limit.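

Among the compounds shown here, the values of compound 1, compound 2 and compound 3 are all limits, so no step between them can be read. The compounds shown leave open the actual half-maximal cytotoxic concentration of each, and whether changing the group on the aromatic carbon shifts it at all.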